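Acyl isothiourea and isoselenourea analogues: cytotoxicity working notes

The compounds below may be only part of what the source reports. "The series", "measured", "known", "first", "only" and "open" are said of these compounds alone.

Three measured compounds share two acyl groups on a carbon with a double bond to nitrogen. Compound 1 `CS/C(=N\C(=O)c1ccno1)NC(=O)c1ccno1` carries a methylsulfanyl group there, while compound 2 `O=C(/N=C(/NC(=O)c1ccno1)[Se]Cc1ccccc1)c1ccno1` and compound 3 `O=C(/N=C(/NC(=O)c1cc(-c2ccccc2)nc2ccccc12)[Se]Cc1ccccc1)c1cc(-c2ccccc2)nc2ccccc12` carry the selenium-bearing group. In a functional assay on PC-3 cells (Homo sapiens) for cytotoxicity, read by MTT assay, with a stated time of 72 h (a lower number here means that less compound is tolerated, a higher number that more compound is tolerated), compound 1 gives only a limit of the assay, > 100000 nM. Compound 2 in this assay likewise reaches only a limit, > 100000 nM. Compound 3 in this assay also stays at a limit, > 100000 nM. The step that the two limits leave unreadable from compound 2 to compound 1 is a group of 2 heavy atoms (1 carbon, 1 sulfur; no ring) in place of a group of 8 heavy atoms (7 carbon, 1 selenium; one six-membered aromatic ring of carbon only), on a carbon with a double bond to nitrogen; its size cannot be read, as the limit of > 100000 nM in this assay, at which 3 of the 3 values shown sit, shows. The difference between the cores of compound 2 and compound 3 is not broken down here. Compound 4 `CS/C(=N\C(=O)c1cc(-c2ccccc2)nc2ccccc12)NC(=O)c1cc(-c2ccccc2)nc2ccccc12` is not yet measured; it differs from compound 3 by a group of 2 heavy atoms (1 carbon, 1 sulfur; no ring) in place of a group of 8 heavy atoms (7 carbon, 1 selenium; one six-membered aromatic ring of carbon only), on a carbon with a double bond to nitrogen, the same change at the same place as between compound 2 and compound 1. The step that the limit leaves unreadable from compound 3 to compound 4 is expected to be small or unreadable, an expectation that rests on a step that the two limits leave unreadable from compound 2 to compound 1. It rests also on compound 3 standing at > 100000 nM, a limit. Compound 4 is therefore estimated at 150000 nM, between 50000 nM and 500000 nM, most likely again reported only as a limit.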

Compound 4, concentration lethal to 50% of the cells: > 100000 nM
Compound 4: no number, only a limit (the forecaster's own chance of this, stated with the estimate: 80%); the middle value lies beyond the limit too.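

No new step can be read from compound 4: the change of the selenium-bearing group to methylsulfanyl has no readable size, either between compound 3 and compound 4 or between compound 2 and compound 1: the limit of > 100000 nM in this assay, at which 4 of the 4 values shown sit.

The compounds shown leave open whether this change alters cytotoxicity at all, and whether either core has any measurable cytotoxicity.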